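A few compounds are considered here, and "the series" means these few. Any claim that something is new, unique, unknown or untested is made for them only; others in the source may bear on it.

In an ADME assay on Huh-5-2 cells (Homo sapiens) for cytotoxicity, read by WST assay, with a stated time of 3 days (a lower number here means that less compound is tolerated, a higher number that more compound is tolerated), compound 1 `COc1ccccc1COc1c(-c2ccccc2)oc2cc(O)cc(O)c2c1=O` gives 53000 nM, and compound 2 `O=c1c(OCc2ccc(Br)cc2)c(-c2ccccc2)oc2cc(O)cc(O)c12` gives 2000 nM. Among the measured compounds shown here, the single measured step, a 27-fold lower number from compound 1 to compound 2 (1.42 log units; beyond the scatter), is the only comparison available, so compound 2 stands as the lowest of the two numbers, meaning less of it is tolerated by the cells than of compound 1.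

Compound 3 `O=c1c(OCc2ccc([N+](=O)[O-])cc2)c(-c2ccccc2)oc2cc(O)cc(O)c12` keeps the shared core and the benzyl ether and differs from compound 2 only in nitro in place of bromo on an aromatic carbon. For the measured compounds named here, no measured step exchanges bromo for nitro; the one known step, a 27-fold lower number from compound 1 to compound 2 (1.42 log units; beyond the scatter), swaps a different pair of groups on that same benzyl ring and was large. It shows that this position can shift the number strongly in this assay, but it gives no direction for the present exchange. The expectation is therefore a modest step, a 2.5-fold higher number from compound 2 to compound 3 (0.40 log units; beyond the scatter), with wide uncertainty, because a 27-fold lower number from compound 1 to compound 2 (1.42 log units; beyond the scatter) demonstrates how sensitive this assay is to the group on this ring. Compound 3 is estimated at 5000 nM, within 1500 nM to 20000 nM.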

Compound 3, half-maximal cytotoxic concentration: 40000 nM
Beside the measured number, compound 3's estimate is 8.0-fold (0.90 log units) below it; measured number outside the range, above it.
By their numbers in this assay, from the lowest: compound 2; then compounds 3 and 1 (each within the scatter of the next).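

In this assay the exchange of bromo for nitro on an aromatic carbon para to a large group is itself a large step, with a 20-fold higher number from compound 2 to compound 3 (1.30 log units; beyond the scatter) showing that this single change can undo nearly all of the earlier drop on this ring. The 4-nitrophenyl and 2-methoxyphenyl versions cannot be told apart, as a 1.3-fold lower number from compound 1 to compound 3 (0.12 log units; within the scatter) shows, so among these three compounds only the 4-bromophenyl group of compound 2 stands apart, with its steps to both others beyond the scatter. No measurement at hand explains why this one group stands out or why the step is so large.

As far as these compounds go, whether the low number belongs to bromo alone or is shared by other halogens remains open, and chloro or fluoro on the same aromatic carbon would test that directly. From the compounds shown here alone, it is also open how an amine or a carboxylic acid at that place would read in this assay, and whether a group such as methyl would fall with compound 2 or sit with the other two compounds.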